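Ester homologation in the sulfamide piperidine series

The compounds below may be only part of what the source reports. "The series", "measured", "known", "first", "only" and "open" are said of these compounds alone.

Measured compounds:
compound 1 `NS(=O)(=O)NCC1CCN(c2cc(-c3ccc(Cl)cc3)ncn2)CC1`: 25500 nM
compound 2 `COC(=O)c1ccc(-c2cc(N3CCC(CNS(N)(=O)=O)CC3)ncn2)cc1`: 17700 nM

For the measured compounds named here, in a functional assay on MCF7 cells (Homo sapiens) for antiproliferative activity, read by sulforhodamine B assay, with a stated time of 48 h (a lower number here means a stronger inhibitor of growth, a higher number a weaker inhibitor of growth), compound 2 and compound 1 sit within the scatter of each other, the only measured step being a 1.4-fold lower number from compound 1 to compound 2 (0.16 log units; within the scatter). Compound 3 `CCOC(=O)c1ccc(-c2cc(N3CCC(CNS(N)(=O)=O)CC3)ncn2)cc1` differs from compound 2 by methyl in place of hydrogen on a saturated chain carbon bound to an oxygen next to a carbonyl group. Going by the values given here, no measured step touches this place, and the single step available alters the aromatic substituent instead. With nothing in the series pointing either way, the expected step is a 1.0-fold higher number from compound 2 to compound 3 (0.01 log units; within the scatter), none beyond the scatter. Compound 3 is therefore estimated at 18000 nM, with a range of 8000 nM to 40000 nM.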

Compound 3, concentration for 50% growth inhibition: 4100 nM
The estimate for compound 3 lay 4.4-fold (0.64 log units) above the measured number; the measured number lies below the stated range.
By their numbers in this assay, from the lowest: compound 3; then compounds 2 and 1 (each within the scatter of the next).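

The change from methoxycarbonyl to ethoxycarbonyl brings a 4.3-fold lower number from compound 2 to compound 3 (0.64 log units; beyond the scatter) in this assay and shows that this saturated chain carbon bound to an oxygen responds to a single methyl, which the earlier aromatic exchange could not show. Against chloro, the ethyl ester brings a 6.2-fold lower number from compound 1 to compound 3 (0.79 log units; beyond the scatter) while the methyl ester stayed within the scatter of compound 1. No available evidence bears on the origin of this difference.

From the compounds shown here alone, whether a longer chain such as propoxycarbonyl extends the step remains open. So does whether a carboxylic acid or an amide at this aromatic carbon holds the level of compound 3.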